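Aryl variation on the chain alkene of a diol series

This account rests on a few compounds, and the source may have more. Where it says the series, first, only, none or still open, it means among the compounds named here.

Measured in a functional assay on HeLa cells (Homo sapiens) for cytotoxicity, read by MTT assay, with a stated time of 48 h; a lower number here means a stronger inhibitor, a higher number a weaker inhibitor:
compound 1 `CC1(C)CCC[C@]2(C)[C@@H](CC[C@@](C)(O)/C=C/c3ccccc3)[C@](C)(O)CC[C@@H]12`: 3320 nM
compound 2 `Cc1ccc(C)c(/C=C/[C@](C)(O)CC[C@@H]2[C@@]3(C)CCCC(C)(C)[C@@H]3CC[C@@]2(C)O)c1`: 3380 nM
compound 3 `CC1(C)CCC[C@]2(C)[C@@H](CC[C@@](C)(O)/C=C/c3ccc(Cl)nc3)[C@](C)(O)CC[C@@H]12`: 3680 nM

Compound 2 gives the second highest of the three numbers; its nearest neighbour is compound 1 and its furthest is compound 3, both within the scatter. Compound 4 `CC1(C)CCC[C@]2(C)[C@@H](CC[C@@](C)(O)/C=C/c3ccc(C(=O)O)cc3)[C@](C)(O)CC[C@@H]12` differs from compound 2 only at the aryl group: 4-carboxyphenyl in place of 2,5-dimethylphenyl on a double-bonded chain carbon bound to a double-bonded chain carbon.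

Among the measured compounds shown here, the steps that bear on this change are the three aryl swaps among the measured compounds: a 1.0-fold higher number from compound 1 to compound 2 (0.01 log units; within the scatter), a 1.1-fold higher number from compound 1 to compound 3 (0.04 log units; within the scatter) and a 1.1-fold higher number from compound 2 to compound 3 (0.04 log units; within the scatter). All three were within the scatter, so varying the aryl group on this chain carbon has so far left this assay essentially unmoved. For compound 4 no step beyond the scatter is expected: a 1.0-fold higher number from compound 2 to compound 4 (0.02 log units; within the scatter). Compound 4 is estimated at 3500 nM, within 1400 nM to 9000 nM.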

Compound 4, half-maximal inhibitory concentration: 45400 nM
The estimate for compound 4 lay 13-fold (1.11 log units) below the measured number; measured number above the stated range.
By their numbers in this assay, from the lowest: compounds 1, 2 and 3 (each within the scatter of the next); then compound 4.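

In this assay the aryl group on this chain carbon turns out not to be indifferent: the number rises with a 13-fold higher number from compound 2 to compound 4 (1.13 log units; beyond the scatter) and with a 12-fold higher number from compound 3 to compound 4 (1.09 log units; beyond the scatter) and with a 14-fold higher number from compound 1 to compound 4 (1.14 log units; beyond the scatter) while the earlier aryl swaps all stayed within the scatter. Among the compounds shown here, the last step is the single change of carboxy in place of hydrogen on an aromatic carbon, so the shift goes with that one group in this set. Nothing available accounts for the shift. Still open, as far as these compounds go, is whether a methyl ester or a primary amide on that aromatic carbon would behave like the carboxy group or like the earlier aryl groups.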